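This account rests on a few compounds, and the source may have more. Where it says the series, first, only, none or still open, it means among the compounds named here.

Compound 1 `CCCn1c(=O)[nH]c2nc(-c3ccc(S(=O)(=O)N4CCN(c5cccc(Cl)c5)CC4)cc3)[nH]c2c1=O`: > 1000 nM
Compound 2 `CCCn1c(=O)[nH]c2nc(-c3ccc(S(=O)(=O)N4CCN(c5ccccc5)C(C)C4)cc3)[nH]c2c1=O`: > 1000 nM

In an assay on CHO cells for displacement of a labelled ligand from adenosine receptor A1 (Homo sapiens), read by scintillation counting, with a stated time of 90 min, in the presence of a further agent that is not named here (on this read-out higher numbers stand for weaker inhibition and lower numbers for stronger inhibition), compound 1 gives > 1000 nM, which is a limit of the assay rather than a number. Compound 2 likewise gives > 1000 nM, again a limit. Both results sit at the limit of > 1000 nM in this assay, at which 2 of the 2 values shown sit, so nothing here places compound 1 above or below its neighbour. Compound 3 `CCCn1c(=O)[nH]c2nc(-c3ccc(S(=O)(=O)N4CCN(Cc5ccc(Br)c(F)c5)CC4)cc3)[nH]c2c1=O` has not yet been measured; it differs from compound 1 by 4-bromo-3-fluorobenzyl in place of 3-chlorophenyl on an amine nitrogen in a ring. For the measured compounds named here, no measured pair tests this change, so no step beyond the scatter is expected in this assay. Compound 3 is expected to give 3000 nM, between 800 nM and 20000 nM, most likely again reported as a limit. The expected step is a step that the limit leaves unreadable from compound 1 to compound 3.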

Compound 3, inhibition constant: 326 nM
Compound 3: the middle estimate sits 9.2-fold (0.96 log units) above what was measured, and the stated range ends above it.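

In this assay, 4-bromo-3-fluorobenzyl in place of 3-chlorophenyl on the amine nitrogen gives an at least 3.0-fold lower number from compound 1 to compound 3 (0.48 log units; beyond the scatter). The earlier compounds could not show that a change at this nitrogen moves the read-out, and compound 3 alone gives a readable number: the limit of > 1000 nM in this assay, at which 2 of the 3 values shown sit.

The compounds shown leave open whether the step goes with the benzyl form or with the bromine and fluorine. A plain benzyl or a 3-chlorobenzyl group on this nitrogen would separate the two.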